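A few compounds are considered here, and "the series" means these few. Any claim that something is new, unique, unknown or untested is made for them only; others in the source may bear on it.

Measured so far:
- compound 1 `C=C1C(=O)O[C@@H]2C/C(CO)=C\CC[C@@H](CO)C[C@@H](OC(=O)/C(C)=C\C)[C@@H]12`: 3000 nM
- compound 2 `C=C(C)C(=O)O[C@@H]1C[C@H](CO)CC/C=C(/C=O)C[C@H]2OC(=O)C(=C)[C@H]12`: 1500 nM

In an ADME assay on Bel-7402 cells (Homo sapiens) for cytotoxicity, read by sulforhodamine B assay, with a stated time of 72 h (a lower number here means a stronger inhibitor, a higher number a weaker inhibitor), compound 2 gives 1500 nM. This lies within the usual scatter of compound 1 at 3000 nM, so the two numbers do not separate.

Compound 3 `C=C(C)C(=O)O[C@@H]1C[C@H](CO)CC/C=C(/CO)C[C@H]2OC(=O)C(=C)[C@H]12` has not yet been measured. Its difference from compound 2 is hydroxymethyl in place of formyl on a double-bonded ring carbon. The rest of the structure is unchanged.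

Among the compounds with values here, no measured pair isolates this change, so the data give no direct size for it. The closest guide is compound 1, which gives 3000 nM and also carries hydroxymethyl on a double-bonded ring carbon, though it differs from compound 3 elsewhere as well. On that slim basis, a small move towards a higher number is expected in this assay, quite possibly none beyond the scatter. The estimated change is a 1.5-fold higher number from compound 2 to compound 3 (0.17 log units; within the scatter). For compound 3 the estimated value is 2200 nM, with an expected range of 900 nM to 5500 nM.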

Compound 3, half-maximal inhibitory concentration: 1720 nM
The estimate for compound 3 lay 1.3-fold (0.11 log units) above the measured number; measured number inside the range.
By their numbers in this assay, from the lowest: compounds 2, 3 and 1 (each within the scatter of the next).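

In this assay, within the data shown here, hydroxymethyl in place of formyl on a double-bonded ring carbon gives a first direct reading at this position (a 1.1-fold higher number from compound 2 to compound 3 (0.06 log units; within the scatter)), and the two groups do not separate, even though only hydroxymethyl carries a hydrogen-bond donor. Among these compounds, the same compound 3 also gives the series a first direct reading of the ester side, where 1-methylethenyl in place of 1-methylprop-1-en-1-yl on a carbonyl carbon (a 1.7-fold lower number from compound 1 to compound 3 (0.24 log units; within the scatter)) likewise stays within the scatter, so neither single change separates the numbers in this assay. No measurement on hand bears on why these two changes leave the numbers inseparable.

As far as these compounds go, both readings rest on one pair each and cover only these groups, so it remains open whether a carboxylic acid, an aminomethyl group or a longer chain on the same double-bonded ring carbon would give a step beyond the scatter. Also open, from the compounds shown here alone, is whether the two changes would behave the same way on another version of the shared core, or in any cell line other than the one tested here.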